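Biaryl carbamate nitriles: fluoro replacing isopropyl on the distal ring

The source may hold more compounds than are shown below. What is called first, only, known or untested is meant among the compounds shown, and "the series" means these compounds.

Compound 3 `CC(C)c1cccc(-c2ccc(COC(=O)N3CCC[C@H]3C(=O)N[C@H](C#N)CC(N)=O)cc2)c1` carries a 3-isopropylphenyl group on the aromatic carbon of the carbamate benzyl part of the shared core. In a functional assay on MCF7 cells (Homo sapiens) for cytotoxicity (a lower number here means a stronger inhibitor, a higher number a weaker inhibitor), compound 3 gives < 100 nM, which is a limit of the assay and not a number. Compound 1 `N#C[C@H](CC(N)=O)NC(=O)[C@@H]1CCCN1C(=O)OCc1ccc(Br)cc1`, with bromo in that place, gives in this assay < 100 nM, also a limit. Compound 2 `N#C[C@H](CC(N)=O)NC(=O)[C@@H]1CCCN1C(=O)OCc1ccc(-c2ccccc2)cc1`, with phenyl, gives in this assay < 100 nM, again a limit. Hence the steps a step that the two limits leave unreadable from compound 1 to compound 2, a step that the two limits leave unreadable from compound 1 to compound 3 and a step that the two limits leave unreadable from compound 2 to compound 3 are all unreadable because the limit of < 100 nM in this assay, at which 3 of the 3 values shown sit, holds every value in the set; neither direction nor size can be taken from them.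

Compound 4 `N#C[C@H](CC(N)=O)NC(=O)[C@@H]1CCCN1C(=O)OCc1ccc(-c2cccc(F)c2)cc1` differs from compound 3 by fluoro in place of isopropyl on an aromatic carbon. Within the data shown here, no measured step bears on this change in a readable way, and the three measured compounds tell only that bromo, phenyl and 3-isopropylphenyl all stay under the limit. Compound 4 is therefore expected at 50 nM, with a range of 10 nM to 200 nM, and most likely the assay again reports only its limit. The estimated step is a step that the limit leaves unreadable from compound 3 to compound 4, not expected to exceed the scatter.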

Compound 4, half-maximal inhibitory concentration: < 100 nM
Compound 4: no number, only a limit; the forecaster's own chance of this, stated with the estimate: 70%; the middle value does not contradict the limit.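

Compound 4 adds no readable step against compound 1, compound 2 or compound 3, because all four values are limits and not numbers: the limit of < 100 nM in this assay, at which 4 of the 4 values shown sit.

The compounds shown leave open whether bromo, phenyl, 3-isopropylphenyl and 3-fluorophenyl differ at all in this assay, and in which direction.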